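Cytotoxicity notes on aryl piperazine amides, compound 3

The source may hold more compounds than are shown below. What is called first, only, known or untested is meant among the compounds shown, and "the series" means these compounds.

Among the measured compounds shown here, compound 2 `COc1ccccc1N1CCN(C(=O)CN(Cc2ccccc2)c2ccc(Cl)cc2)CC1` stands alone as the one number in this set: in a toxicity assay on C8166 cells (Homo sapiens) for cytotoxicity, read by MTT assay, with a stated time of 72 h (on this read-out lower numbers stand for higher toxicity in this test and higher numbers for lower toxicity in this test), compound 2 gives 228000 nM. Compound 1 `O=C(CN(Cc1ccccc1)c1ccc(Cl)cc1)N1CCN(c2ccccc2)CC1` reaches only a limit, > 954000 nM, in this assay (the limit of > 954000 nM in this assay, at which 1 of the 2 values shown sits). For the measured compounds named here, the single measured step, an at least 4.1-fold lower number from compound 1 to compound 2 (0.62 log units; beyond the scatter), adds a methoxy. Compound 3 `O=C(CN(Cc1ccccc1)c1ccc(Cl)cc1)N1CCN(c2ccc([N+](=O)[O-])cc2)CC1` differs from compound 2 by 4-nitrophenyl in place of 2-methoxyphenyl on an amine nitrogen in a ring. Going by the values given here, no measured step covers a nitro group, and the methoxy of compound 2 leaves, so part of an at least 4.1-fold lower number from compound 1 to compound 2 (0.62 log units; beyond the scatter) may be undone. Compound 3 is therefore expected to give 420000 nM (range 130000 nM to 1300000 nM). The expected step is a 1.8-fold higher number from compound 2 to compound 3 (0.27 log units; within the scatter).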

Compound 3, half-maximal cytotoxic concentration: > 430000 nM
Compound 3 gave a limit, no number; the forecaster's own chance of this, stated with the estimate: 40%; at least 1.0-fold (0.01 log units) between middle value and limit.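

In this assay, 4-nitrophenyl in place of 2-methoxyphenyl on the amine nitrogen in the ring gives an at least 1.8-fold higher number from compound 2 to compound 3 (0.27 log units; that floor lies within the scatter) and so sets only a floor on this change. Compound 3 gives a limit and not a number. Among the compounds shown here, the step from compound 1 to compound 3 cannot be read, as both values are limits, and compound 2 keeps the only number in the set.

On these data alone, how far compound 3 truly lies from compound 2 stays open. Also open, as far as these compounds go, is what an amine or a carboxylic acid on that phenyl ring would give in this assay at this position.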